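Compound 3 to compound 4: a ring group exchanged

The source may hold more compounds than are shown below. What is called first, only, known or untested is meant among the compounds shown, and "the series" means these compounds.

Of the compounds shown here, three sharing one core have been measured so far in a physicochemical assay for solubility, measured as kinetic solubility, at pH 2; a lower number here means a less soluble compound, a higher number a more soluble compound. Compound 1 `CC(C)C(c1ccc(-c2ccc3cccc(F)c3c2)[nH]c1=O)C1NC(=O)NC1=O` gives 5800 nM there, compound 2 `CC(C)C(c1ccc(-c2ccc3cccc(F)c3c2)[nH]c1=O)C1SC(=O)NC1=O` gives 11300 nM and compound 3 `C/C(=C1/OC(=O)NC1=O)C(c1ccc(-c2ccc3cccc(F)c3c2)[nH]c1=O)C(C)C` gives 12700 nM as the starting point for what follows. Where compound 3 stands is plain from two steps: a 1.1-fold higher number from compound 2 to compound 3 (0.05 log units; within the scatter) is no separation at all, and a 2.2-fold higher number from compound 1 to compound 3 (0.34 log units; beyond the scatter) is a modest one.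

Compound 4 `CC(C)C(/C=C1/C(=O)NC(=O)N1C)c1ccc(-c2ccc3cccc(F)c3c2)[nH]c1=O` has not yet been measured. It carries a group of 9 heavy atoms (5 carbon, 2 nitrogen, 2 oxygen; one five-membered non-aromatic ring with 2 hetero atoms) in place of a group of 9 heavy atoms (5 carbon, 1 nitrogen, 3 oxygen; one five-membered non-aromatic ring with 2 hetero atoms), on a saturated chain carbon bound to an aromatic carbon and a saturated chain carbon as its single structural difference. For the measured compounds named here, the steps that bear on this change are the other exchanges of the group at that same place. Beside the two already given there is a 1.9-fold higher number from compound 1 to compound 2 (0.29 log units; within the scatter) and this too stays small. Going by the values given here, no exchange of this group measured so far has moved the number by more than the modest 2.2-fold higher number from compound 1 to compound 3 (0.34 log units; beyond the scatter) in the set, and none of these groups is the one that enters in compound 4. No step beyond the scatter is therefore expected in this assay, and no direction can be argued with any confidence.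

For compound 4 the estimate is 9500 nM as a central value, with the expected range running from 4000 nM to 22000 nM in this reading. The estimate means an expected change of a 1.3-fold lower number from compound 3 to compound 4 (0.13 log units; within the scatter) overall.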

Compound 4, solubility: 8300 nM
Compound 4: the middle estimate sits 1.1-fold (0.06 log units) above what was measured, and the stated range covers the measured number.
By their numbers in this assay, from the lowest: compounds 1, 4, 2 and 3 (each within the scatter of the next, the first and the last beyond it).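

In this assay, the group entering on a saturated chain carbon bound to an aromatic carbon and a saturated chain carbon stays within the scatter of all three earlier groups, with a 1.5-fold lower number from compound 3 to compound 4 (0.18 log units; within the scatter), a 1.4-fold lower number from compound 2 to compound 4 (0.13 log units; within the scatter) and a 1.4-fold higher number from compound 1 to compound 4 (0.16 log units; within the scatter). The exchange from compound 3 to compound 4 keeps the count of 9 heavy atoms and 5 carbon, with 2 nitrogen and 2 oxygen in place of 1 nitrogen and 3 oxygen, and this new kind of exchange leaves the number within the scatter, while the only separation beyond it in the set remains a 2.2-fold higher number from compound 1 to compound 3 (0.34 log units; beyond the scatter), with compound 4 within the scatter of both of those compounds. No measurement offered here gives a reason for these small steps.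

Going by these compounds, all four groups at this place are five-membered non-aromatic rings with 2 hetero atoms, so it stays open whether a carboxylic acid or an amine there would give a step beyond the scatter. Also open, on these data alone, is whether an open-chain urea or a six-membered ring would stay as close to these four compounds in this assay.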